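A few compounds are considered here, and "the series" means these few. Any claim that something is new, unique, unknown or untested is made for them only; others in the source may bear on it.

Measured so far in a functional assay on HepG2 cells (Homo sapiens) for antiproliferative activity, read by MTT assay; a lower number here means a stronger inhibitor, a higher number a weaker inhibitor:
- compound 1, `CCNC(=O)c1oc2nc(-c3ccccc3)cc(C(F)(F)F)c2c1N`: 42800 nM
- compound 2, `Nc1c(C(=O)N/N=C/c2ccccc2)oc2nc(-c3ccccc3)cc(C(F)(F)F)c12`: 13100 nM
- compound 3, `CNC(=O)c1oc2nc(-c3ccccc3)cc(C(F)(F)F)c2c1N`: 41200 nM

Compound 3 stands second highest of the three numbers in this assay; its nearest neighbour is compound 1, a 1.0-fold lower number from compound 1 to compound 3 (0.02 log units; within the scatter), and its furthest is compound 2, a 3.1-fold higher number from compound 2 to compound 3 (0.50 log units; beyond the scatter).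

Compound 4, `Nc1c(C(=O)N/N=C/c2ccc(Cl)cc2)oc2nc(-c3ccccc3)cc(C(F)(F)F)c12`, is not yet measured. It differs from compound 3 by a group of 9 heavy atoms (7 carbon, 1 nitrogen, 1 chlorine; one six-membered aromatic ring of carbon only) in place of one carbon atom, on an amide-type nitrogen.

Among the compounds with values here, two measured steps bear on this change. Both exchange a small alkyl on the amide-type nitrogen for a benzylidene-amino group: a 3.3-fold lower number from compound 1 to compound 2 (0.51 log units; beyond the scatter), and in reverse a 3.1-fold higher number from compound 2 to compound 3 (0.50 log units; beyond the scatter). Within the data shown here, the chlorine on the incoming ring has no counterpart among the measured compounds, so nothing can be said about it from these data; the expectation rests on the ring exchange alone.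

A step of similar size and direction is therefore expected, a 3.7-fold lower number from compound 3 to compound 4 (0.57 log units; beyond the scatter), with the chlorine left as an open uncertainty widening the range. Compound 4 is estimated at 11000 nM in this assay, within 4000 nM to 30000 nM.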

Compound 4, half-maximal inhibitory concentration: 12100 nM
The estimate for compound 4 lay 1.1-fold (0.04 log units) below the measured number; measured number inside the range.
By their numbers in this assay, from the lowest: compounds 4 and 2 (each within the scatter of the next); then compounds 3 and 1 (each within the scatter of the next).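

In this assay, chloro in place of hydrogen on an aromatic carbon leaves the number unchanged within the scatter (a 1.1-fold lower number from compound 2 to compound 4 (0.03 log units; within the scatter)), so on this evidence the chlorine neither adds to nor takes from the ring exchange. The step on the amide-type nitrogen persists with the chlorinated group in place, both against the methyl amide (a 3.4-fold lower number from compound 3 to compound 4 (0.53 log units; beyond the scatter)) and against the ethyl amide (a 3.5-fold lower number from compound 1 to compound 4 (0.55 log units; beyond the scatter)), and compounds 2 and 4 now both stand apart from compounds 1 and 3. No supporting evidence is available to explain this step.

Going by these compounds, whether a methoxy or nitro group on that aromatic ring would behave as chloro does remains open. Also open, on these data alone, is whether the aromatic ring itself matters, or whether a longer alkyl chain on the amide-type nitrogen would give the same step.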